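Isobutyl to sec-butyl: a step against a limit

The compounds below may be only part of what the source reports. "The series", "measured", "known", "first", "only" and "open" are said of these compounds alone.

In a functional assay on MCF7 cells (Homo sapiens) for inhibition, read by MTT assay, with a stated time of 72 h (a lower number here means a stronger inhibitor, a higher number a weaker inhibitor), compound 2 `CC(C)C[C@H](NC(=O)c1cc(Cl)ccc1OCCNC(=O)OC(C)(C)C)C(=O)Nc1ccc([N+](=O)[O-])cc1Cl` gives > 10000 nM as a limit, not a number. Compound 1 `C[C@H](NC(=O)c1cc(Cl)ccc1OCCNC(=O)OC(C)(C)C)C(=O)Nc1ccc([N+](=O)[O-])cc1Cl` gives > 10000 nM as a limit too. Compound 3 `CC(C)C[C@H](NC(=O)c1cc(Cl)ccc1OCCN)C(=O)Nc1ccc([N+](=O)[O-])cc1Cl` gives > 10000 nM as a limit too. These three offer only the limit of > 10000 nM in this assay, at which 3 of the 3 values shown sit, and nothing finer.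

Compound 4 `CC[C@@H](C)[C@H](NC(=O)c1cc(Cl)ccc1OCCNC(=O)OC(C)(C)C)C(=O)Nc1ccc([N+](=O)[O-])cc1Cl` keeps the core of compound 2 and rearranges one side group: sec-butyl in place of isobutyl on a saturated chain carbon bound to an amide-type nitrogen and a carbonyl carbon gives sec-butyl in place of isobutyl on a saturated chain carbon bound to an amide-type nitrogen and a carbonyl carbon.

Within the data shown here, two measured steps bear on this change: a step that the two limits leave unreadable from compound 1 to compound 2 at that same chain carbon, and a step that the two limits leave unreadable from compound 2 to compound 3 on an amine nitrogen. Neither has a size that can be carried over, so no step beyond the usual scatter is expected in this assay and no direction can be favoured. The expected change is a step that the limit leaves unreadable from compound 2 to compound 4 and amounts to no real shift. Compound 4 is estimated at 15000 nM with an expected range of 7000 nM to 30000 nM and will most likely be reported as a limit again.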

Compound 4, half-maximal inhibitory concentration: 10500 nM
Compound 4: the middle estimate sits 1.4-fold (0.15 log units) above what was measured; low and high end bracket the measured number.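

Among these compounds, compound 4 gives a measured number, but compound 1 and compound 2 each carry only a limit, so no step to compound 4 can be read from either: the limit of > 10000 nM in this assay, at which 3 of the 4 values shown sit. The compounds shown leave open how sec-butyl truly compares with isobutyl or methyl at this chain carbon.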